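The source may hold more compounds than are shown below. What is called first, only, known or untested is meant among the compounds shown, and "the series" means these compounds.

Measured compounds:
compound 1 `O=C(/C=C/c1ccc(/C=C/C(=O)c2ccccc2)o1)NO` with 22800 nM
compound 2 `O=C(/C=C/c1ccc(/C=C/C(=O)c2ccc(Cl)cc2)o1)NO` with 6030 nM

Both were tested in an assay on isolated protein for inhibition of histone deacetylase 4 (Homo sapiens), read by fluorescence; a higher number here means a weaker inhibitor, a lower number a stronger inhibitor. Among the two numbers, compound 2 holds the lower one, and the only other, compound 1, gives a number that is higher by a 3.8-fold lower number from compound 1 to compound 2 (0.58 log units; beyond the scatter), a difference that the repeat scatter of this kind of test does not explain; that single step is all the guidance there is. Compound 3 `CC(C)c1ccc(C(=O)/C=C/c2ccc(/C=C/C(=O)NO)o2)cc1` has not yet been tested. It differs from compound 2 by isopropyl in place of chloro on an aromatic carbon. Among the measured compounds shown here, no measured pair shows an exchange of chloro for isopropyl, so the step from compound 1 to compound 2 bears only loosely on it: it shows that this position tolerates a substituent, not what an isopropyl does there. The expected step in this assay from compound 2 to compound 3 is therefore modest, a 1.2-fold higher number from compound 2 to compound 3 (0.06 log units; within the scatter), with a wide range. Compound 3 is estimated at 7000 nM, between 2500 nM and 20000 nM.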

Compound 3, half-maximal inhibitory concentration: 4890 nM
The estimate for compound 3 lay 1.4-fold (0.16 log units) above the measured number; the range from low to high includes it.
By their numbers in this assay, from the lowest: compounds 3 and 2 (each within the scatter of the next); then compound 1.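

In this assay, putting isopropyl in place of chloro on this aromatic carbon gives a 1.2-fold lower number from compound 2 to compound 3 (0.09 log units; within the scatter) and so the two groups cannot be told apart here, even though isopropyl has 3 heavy atoms where chloro has 1. Against hydrogen at the same place, isopropyl gives a 4.7-fold lower number from compound 1 to compound 3 (0.67 log units; beyond the scatter) and this step lies beyond the scatter, so among these compounds the better number is not confined to chlorine but also appears with a group made only of carbon and hydrogen. Nothing available explains why these two groups give such close numbers.

Both groups have 0 hydrogen-bond donors and 0 hydrogen-bond acceptors, so the compounds shown leave open what an amine or a carboxylic acid would do at this position. They also leave open whether a larger group, such as tert-butyl, would keep the number in this range.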